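This account rests on a few compounds, and the source may have more. Where it says the series, first, only, none or still open, it means among the compounds named here.

Compound 1 `C/C1=C\CC[C@@]2(C)O[C@@H]2[C@H]2OC(=O)[C@@H](CN3CCCC3)[C@@H]2C[C@H]1O` and compound 2 `C/C1=C\CC[C@@]2(C)O[C@@H]2[C@H]2OC(=O)[C@@H](CN3CCN(C)CC3)[C@@H]2C[C@H]1O` share a core and differ only in the amine attached to the saturated chain carbon. In a functional assay on Hs 683 cells (Homo sapiens) for inhibition, read by colorimetric assay and MTT assay, with a stated time of 72 h (on this read-out lower numbers stand for stronger inhibition and higher numbers for weaker inhibition), compound 1 gives 15000 nM, while compound 2 gives 33000 nM. The step of a 2.2-fold higher number from compound 1 to compound 2 (0.34 log units; beyond the scatter) is modest, and compound 2 therefore stands as the higher of the two numbers, with compound 1 as its nearest neighbour.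

Compound 3 `COc1ccc(N2CCN(C[C@@H]3C(=O)O[C@H]4[C@H]3C[C@@H](O)/C(C)=C/CC[C@@]3(C)O[C@H]43)CC2)cc1` is reached from compound 2 by the change (4-methoxyphenyl in place of methyl on an amine nitrogen in a ring). Among the measured compounds shown here, no measured pair in this set replaces a group on the ring nitrogen itself; the one step in hand, a 2.2-fold higher number from compound 1 to compound 2 (0.34 log units; beyond the scatter), exchanges one amine ring for another and bears on the new step only loosely, showing that changes around this amine have so far moved this assay by no more than a modest amount. The expectation for compound 3 is thus a step of a 1.7-fold lower number from compound 2 to compound 3 (0.22 log units; within the scatter), with little ground for a direction beyond the scatter. Compound 3 is estimated at 20000 nM, within a range from 5000 nM to 80000 nM.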

Compound 3, half-maximal inhibitory concentration: 22000 nM
Compound 3: the middle estimate sits 1.1-fold (0.04 log units) below what was measured; low and high end bracket the measured number.
By their numbers in this assay, from the lowest: compounds 1, 3 and 2 (each within the scatter of the next, the first and the last beyond it).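

Among the compounds shown here, the step on the amine nitrogen in the ring is the first that replaces a group on that nitrogen itself, and in this assay it reads as a 1.5-fold lower number from compound 2 to compound 3 (0.18 log units; within the scatter), so compound 2 and compound 3 cannot be told apart. Methyl, with 1 heavy atom and no ring, gives way here to 4-methoxyphenyl, with 8 heavy atoms and a six-membered aromatic ring of carbon only, and this large difference in the group leaves no readable difference in the number, so at this nitrogen the read-out accepts a far larger group than the methyl of compound 2. Nothing available explains why this exchange leaves the two numbers so close.

The compounds shown leave open whether any group on this nitrogen can move the number beyond the scatter, for instance a plain hydrogen, an acetyl group or a longer alkyl chain ending in a carboxylic acid. They also leave open whether the methoxy group counts at all, which a plain phenyl or a 4-hydroxyphenyl on the same nitrogen would address.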